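From Ethyl Ester to Free Acid in a Lipoxygenase Series

The source may hold more compounds than are shown below. What is called first, only, known or untested is meant among the compounds shown, and "the series" means these compounds.

Among the three measured compounds, compound 3 `CCCCC(Sc1ccc(OCCCOc2ccc3ncccc3c2)cc1)C(=O)OCC` is the only one that gives a number in an assay on isolated protein for inhibition of Polyunsaturated fatty acid 5-lipoxygenase (Homo sapiens), read by HPLC, with a stated time of 15 min, in the presence of a further agent that is not named here; on this read-out lower numbers stand for stronger inhibition and higher numbers for weaker inhibition: compound 3 reaches 800 nM. Compound 1 `CCCCC(Sc1ccc(OCCCOc2ccccc2OC)cc1)C(=O)O` stops at the limit of this assay, with compound 1 reported as > 10000 nM. Compound 2 `CCCCC(Sc1ccc(OCCCOc2cccc3c2CCCC3)cc1)C(=O)OCC` likewise stops at a limit, compound 2 being reported as > 10000 nM. Two of three values therefore rest on (the limit of > 10000 nM in this assay, at which 2 of the 3 values shown sit). Within the data shown here, the single measured step, an at least 12-fold lower number from compound 2 to compound 3 (1.09 log units; beyond the scatter), alters the aryl end of the chain, not the ester.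

Compound 4 `CCCCC(Sc1ccc(OCCCOc2ccc3ncccc3c2)cc1)C(=O)O` differs from compound 3 by hydrogen in place of ethyl on an oxygen next to a carbonyl group. Among the measured compounds shown here, no measured step covers this particular change: compound 1 and compound 2 differ from each other in two places at once, and both are limits, so they show only that their combination of features fails to register. The expectation for compound 4 is therefore a step of a 1.9-fold higher number from compound 3 to compound 4 (0.27 log units; within the scatter), a modest weakening that stays close to the scatter. Compound 4 is estimated at 1500 nM, within a range from 300 nM to 8000 nM.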

Compound 4, half-maximal inhibitory concentration: > 10000 nM
Compound 4 ended at the assay's limit; the forecaster's own chance of this, stated with the estimate: 20%; middle value at least 6.6-fold (0.82 log units) away from the limit.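

In this assay, the ester position matters as well as the aryl end: with the quinolin-6-yl end held fixed, hydrogen in place of ethyl on an oxygen next to a carbonyl group gives an at least 12-fold higher number from compound 3 to compound 4 (1.09 log units; beyond the scatter). The quinolin-6-yl group alone therefore does not secure a readable number, and among the compounds shown only the pairing of that group with the ethyl ester in compound 3 does. The step gives only a minimum size, and the comparison with compound 1 cannot be read: the limit of > 10000 nM in this assay, at which 3 of the 4 values shown sit.

As far as these compounds go, it remains open whether the ethyl group itself is required, or whether a methyl ester, a longer alkyl ester or an amide in place of the ethoxy group would also give a number. From the compounds shown here alone, it also remains open how far other aryl ends can go with the ethyl ester beyond the quinolin-6-yl group.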